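The source may report more compounds than this note shows. Statements on the series, on what has been measured and on what is new or still open speak of the compounds shown alone.

In an ADME assay on a cell-free system (plasma, Rattus norvegicus) for protein binding, compound 3 `CNc1nccc(N2CC[C@H](NC(=O)Nc3ccc(C)c(Cl)c3)C2)n1` stands at 98.9%, the lowest unbound fraction of the three measured compounds. Compound 1 `CNc1nccc(N2CC[C@H](NC(=O)Nc3cc(OC)cc(OC)c3)C2)n1` gives 96.7%, and compound 2 `CNc1nccc(N2CC[C@H](NC(=O)Nc3ccc(OC)cc3)C2)n1` gives 86.3%.

Compound 4 `CNc1nccc(N2CC[C@H](NC(=O)Nc3cccc(OC)c3)C2)n1` has not yet been measured. It differs from compound 3 as follows: 3-methoxyphenyl in place of 3-chloro-4-methylphenyl on an amide-type nitrogen. In words, this is 3-methoxyphenyl in place of 3-chloro-4-methylphenyl on an amide-type nitrogen.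

For the measured compounds named here, one measured step bears on this change: a 12-fold lower unbound fraction from compound 2 to compound 3 (1.10 log units; beyond the scatter). That large step also involves 3-chloro-4-methylphenyl, and the change to compound 4 likewise replaces this group with a methoxy-bearing ring. This suggests a large move in this assay towards more free compound. The evidence is limited, since compound 1 also carries methoxy and still reaches 96.7%, so the move may fall short of the full measured step.

The expected change is a 9.1-fold higher unbound fraction from compound 3 to compound 4 (0.96 log units; beyond the scatter). For compound 4, the estimated value is 90%, with an expected range from 80% to 96.5%.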

Compound 4, plasma protein binding: 93.9%
Compound 4: the middle estimate sits 1.6-fold (0.21 log units) (unbound fraction) above what was measured, within the range that was stated.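

In this assay, the 3-methoxyphenyl group in place of 3-chloro-4-methylphenyl on the amide-type nitrogen leaves more compound free (a 5.5-fold higher unbound fraction from compound 3 to compound 4 (0.74 log units; beyond the scatter)), though compound 4 remains highly bound. For the compounds shown here, the placing of the methoxy on this ring also counts, a point the earlier compounds could not show: 3-methoxyphenyl in place of 4-methoxyphenyl gives a step beyond the scatter (a 2.2-fold lower unbound fraction from compound 2 to compound 4 (0.35 log units; beyond the scatter)). Hydrogen in place of one methoxy of compound 1 gives a step that stays within the scatter (a 1.8-fold higher unbound fraction from compound 1 to compound 4 (0.27 log units; within the scatter)), so these two compounds cannot be told apart in this read-out.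

No measurement at hand offers an explanation for these steps. Still open, as far as these compounds go, is how an amine or a carboxylic acid on this ring would shift the binding.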